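This account rests on a few compounds, and the source may have more. Where it says the series, first, only, none or still open, it means among the compounds named here.

Series notes. Measured in an assay on HEK293 cells for inhibition of Voltage-dependent T-type calcium channel subunit alpha-1G (Homo sapiens), read by fluorescence, tested at 10 uM; a lower number here means less inhibition, a higher number more inhibition at the concentration tested (going by the name of the read-out):

compound 1 `CCCc1nc(-c2ccccc2)c(CNCCCN2CCN(c3ccccc3)CC2)o1`: 43.7%
compound 2 `CCCc1nc(-c2ccccc2)c(CNCCCN2CCN(c3ccccc3F)CC2)o1`: 54.4%
compound 3 `CCCc1nc(-c2ccccc2)c(CNCCCN2CCN(c3ccc(Cl)cc3)CC2)o1`: 63.3%

Compound 3 has the highest number of the three in this assay, but its gap to compound 2 is within the scatter; only its gap to compound 1 is beyond it. Compound 4 `CCCc1nc(-c2ccccc2)c(CNCCCN2CCN(c3cccc(F)c3)CC2)o1` is not yet measured. Its change from compound 3: 3-fluorophenyl in place of 4-chlorophenyl on an amine nitrogen in a ring.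

Going by the values given here, the steps that bear on this: a number 10.7 percentage points higher from compound 1 to compound 2 (beyond the scatter) and a number 19.6 percentage points higher from compound 1 to compound 3 (beyond the scatter), both beyond the scatter; between the two halogenated rings, a number 8.9 percentage points higher from compound 2 to compound 3 (within the scatter), within the scatter. Swapping one halogenated phenyl for another is therefore expected to move the number little, and a slight drop is more likely than a rise, since compound 2 gave 54.4%. The expected step is a number 7.3 percentage points lower from compound 3 to compound 4 (within the scatter), within the scatter. Compound 4 is estimated at 56%, in the range 42% to 68%.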

Compound 4, a percentage reported as inhibition, at one concentration (the size of the read-out at that concentration, not a potency): 68.9%
Compound 4: the middle estimate sits 12.9 percentage points below what was measured; the measured number lies above the stated range.
By their numbers in this assay, from the lowest: compound 1; then compounds 2, 3 and 4 (each within the scatter of the next, the first and the last beyond it).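

Sentence-level reading: in this assay, 3-fluorophenyl in place of 2-fluorophenyl gives a number 14.5 percentage points higher from compound 2 to compound 4 (beyond the scatter) and so shows that, with the same halogen, the place of the fluoro on the phenyl ring changes the number. Against the unsubstituted phenyl ring, the fluoro gives a number 25.2 percentage points higher from compound 1 to compound 4 (beyond the scatter) as its step. The 4-chlorophenyl and 3-fluorophenyl rings are not told apart by a number 5.6 percentage points higher from compound 3 to compound 4 (within the scatter) in this comparison.

No measurement shown accounts for these differences. Still open, going by these compounds, is how 3-chlorophenyl or 3-methoxyphenyl would read on the same ring nitrogen.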